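The compounds below may be only part of what the source reports. "The series", "measured", "known", "first", "only" and "open" are said of these compounds alone.

Measured so far:
compound 1 `COc1ccc(/C=C/C(=O)NNC(=O)c2ccc3c(c2)OCCO3)cc1` — 319000 nM
compound 2 `O=C(/C=C/c1ccc(Br)cc1)NNC(=O)c1ccc2c(c1)OCCO2` — 259000 nM
compound 3 `O=C(/C=C/c1cccc([N+](=O)[O-])c1)NNC(=O)c1ccc2c(c1)OCCO2` — 323000 nM

In an ADME assay on cells (Macrophage) for cytotoxicity, read by MTT assay, with a stated time of 24 h (a higher number here means that more compound is tolerated, a lower number that less compound is tolerated), compound 1 stands with the others: the step of a 1.0-fold higher number from compound 1 to compound 3 (0.01 log units; within the scatter) and the step of a 1.2-fold lower number from compound 1 to compound 2 (0.09 log units; within the scatter) both fall within the scatter, so no ranking of the three is warranted. Compound 4 `O=C(/C=C/c1cccc(Br)c1)NNC(=O)c1ccc2c(c1)OCCO2` is not yet measured; it differs from compound 1 by 3-bromophenyl in place of 4-methoxyphenyl on a double-bonded chain carbon bound to a double-bonded chain carbon. Among the measured compounds shown here, the steps that bear on this change are a 1.2-fold lower number from compound 1 to compound 2 (0.09 log units; within the scatter), which swaps the same pair of groups at another ring position, and a 1.2-fold higher number from compound 2 to compound 3 (0.10 log units; within the scatter), which moves a substituent to the 3-position of the phenyl; neither leaves the scatter. For compound 4 the step of a 1.1-fold lower number from compound 1 to compound 4 (0.04 log units; within the scatter) is therefore expected to stay within the scatter, with an estimate of 290000 nM and a range from 180000 nM to 450000 nM.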

Compound 4, half-maximal cytotoxic concentration: 351000 nM
The estimate for compound 4 lay 1.2-fold (0.08 log units) below the measured number; measured number inside the range.
By their numbers in this assay, from the lowest: compounds 2, 1, 3 and 4 (each within the scatter of the next).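

In this assay the 3-bromophenyl group, on a double-bonded chain carbon bound to a double-bonded chain carbon, does not separate from the 4-methoxyphenyl group (a 1.1-fold higher number from compound 1 to compound 4 (0.04 log units; within the scatter)). Bromo in place of nitro on an aromatic carbon (a 1.1-fold higher number from compound 3 to compound 4 (0.04 log units; within the scatter)) and 3-bromophenyl in place of 4-bromophenyl (a 1.4-fold higher number from compound 2 to compound 4 (0.13 log units; within the scatter)) also stay within the scatter, so this position shows no dependence on these groups so far. No supporting measurement bears on these steps. On these data alone, whether an amine or a carboxylic acid on this phenyl ring would leave the scatter remains open, as do changes to the shared core.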